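Halogen pattern on the anilide ring of the shared core

The source may hold more compounds than are shown below. What is called first, only, known or untested is meant among the compounds shown, and "the series" means these compounds.

Compound 1 `O=C(CSc1nc(Nc2ccccc2)c2ccccc2n1)Nc1ccccc1Br` stands lowest of the two numbers in a functional assay on MDA-MB-231 cells (Homo sapiens) for inhibition, read by MTT assay, with a stated time of 72 h (a lower number here means a stronger inhibitor, a higher number a weaker inhibitor), where compound 1 gives 14100 nM. Compound 3 `O=C(CSc1nc(Nc2ccccc2)c2ccccc2n1)Nc1ccc(F)cc1` is the nearest of the measured set; in this assay compound 3 gives 34100 nM. Compound 2 `O=C(CSc1nc(Nc2ccccc2)c2ccccc2n1)Nc1cccc(F)c1` reaches only a limit of this assay, > 50000 nM, and no number is known for it; (the limit of > 50000 nM in this assay, at which 1 of the 3 values shown sits).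

The measured steps leave the shared core untouched and vary only the aryl group on the amide-type nitrogen. There is an at least 3.5-fold higher number from compound 1 to compound 2 (0.54 log units; beyond the scatter) and a 2.4-fold higher number from compound 1 to compound 3 (0.38 log units; beyond the scatter), so each move away from 2-bromophenyl weakened inhibition. Between the two fluorophenyl compounds there is an at least 1.4-fold lower number from compound 2 to compound 3 (0.16 log units; that floor lies within the scatter), a difference that the limit does not allow to be sized.

Compound 4 `O=C(CSc1nc(Nc2ccccc2)c2ccccc2n1)Nc1ccc(Cl)c(Cl)c1` is not yet measured in this assay. Against compound 1 the change is 3,4-dichlorophenyl in place of 2-bromophenyl on an amide-type nitrogen. For the measured compounds named here, both steps from compound 1 bear on it, since 3,4-dichlorophenyl carries substituents where 3-fluorophenyl and 4-fluorophenyl each carried one, and both raised the number; no measured pair holds chlorine, so the size is uncertain. A weakening step of a 2.0-fold higher number from compound 1 to compound 4 (0.30 log units; within the scatter) is expected. Compound 4 is therefore estimated at 28000 nM, within 10000 nM to 60000 nM.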

Compound 4, half-maximal inhibitory concentration: 14500 nM
Beside the measured number, compound 4's estimate is 1.9-fold (0.29 log units) above it, within the range that was stated.
By their numbers in this assay, from the lowest: compounds 1 and 4 (each within the scatter of the next); then compound 3. At a limit, above all of these: compound 2.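

In this assay there is a 1.0-fold higher number from compound 1 to compound 4 (0.01 log units; within the scatter), so the low end of the set is no longer tied to 2-bromophenyl on the amide-type nitrogen, and a group without bromine reaches the same level. There is also a 2.4-fold lower number from compound 3 to compound 4 (0.37 log units; beyond the scatter), which makes 3,4-dichlorophenyl the first replacement for a fluorophenyl group in this series to lower the number beyond the scatter, and the halogen pattern on this ring now separates the compounds in both directions rather than only weakening inhibition on leaving 2-bromophenyl. The third step starts from a limit and reads only as a floor, with an at least 3.4-fold lower number from compound 2 to compound 4 (0.53 log units; beyond the scatter): the limit of > 50000 nM in this assay, at which 1 of the 4 values shown sits.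

Still open, as far as these compounds go, is whether the level shared by the 2-bromophenyl and 3,4-dichlorophenyl groups follows the heavier halogens or the number of substituents, a question that a chlorophenyl or a difluorophenyl group on the same nitrogen would address. Also open, from the compounds shown here alone, is how this position responds to groups other than halogens, such as methoxy, a nitrile or a carboxylic acid on the ring.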